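Ethoxy in place of methylamino on the shared core

The source may hold more compounds than are shown below. What is called first, only, known or untested is meant among the compounds shown, and "the series" means these compounds.

Measured so far in an ADME assay on microsomes from liver (Mus musculus) for metabolic stability, read by LC-MS, using NADPH, tested at 1 uM; a lower number here means that the compound disappears faster, a higher number that the compound lasts longer:
Compound 1 `Cc1nc2c(N)ncnc2n1[C@@H]1O[C@H](CN(C)C/C=C\CNC(=O)OC(C)(C)C)[C@H]2OC(C)(C)O[C@H]21`: < 0.0417 h
Compound 2 `CNc1ncnc2c1ncn2[C@@H]1O[C@H](CN(C)C/C=C\CN)[C@H]2OC(C)(C)O[C@H]21`: > 1.5 h
Compound 3 `CNc1ncnc2c1ncn2[C@@H]1O[C@H](CN(C)C/C=C\CN)[C@@H](O)[C@H]1O`: > 1.5 h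

All three values are limits of the assay and not numbers. Compound 3 sits at the limit of > 1.5 h in this assay, at which 2 of the 3 values shown sit, and compound 2 shares that limit. Compound 1 sits at the opposite end, at the limit of < 0.0417 h in this assay, at which 1 of the 3 values shown sits.

The next compound to be tested is compound 4 `CCOc1ncnc2c1ncn2[C@@H]1O[C@H](CN(C)C/C=C\CN)[C@@H](O)[C@H]1O`. It carries ethoxy in place of methylamino on an aromatic carbon of a six-membered aromatic ring with 2 nitrogen, part of a fused or bridged system of two rings: ethoxy in place of methylamino on an aromatic carbon. No measured pair among these compounds shows this change or any other single change, so the expectation rests on compound 3 and the structural change alone. The expected step is an at least 1.5-fold lower number from compound 3 to compound 4 (0.17 log units; that floor lies within the scatter), a small shortening in this assay, and its true size is uncertain. For compound 4 the estimated half-life is 1 h, with an expected range of 0.3 h to 2.5 h.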

Compound 4, half-life: > 1.5 h
Compound 4: no number, only a limit; the forecaster's own chance of this, stated with the estimate: 40%; at least 1.5-fold (0.17 log units) between middle value and limit.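

In this assay compound 4 gives > 1.5 h, which is a limit of the assay and not a number. Compound 3 also stands at a limit, so no step can be read between compound 3 and compound 4. The compounds shown leave open how the half-life with ethoxy compares with that with methylamino on the shared core.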